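The compounds below may be only part of what the source reports. "The series", "measured", "known", "first", "only" and "open" are said of these compounds alone.

Notes on the carboxylic-acid series built on the shared core of compound 1 `O=C(O)c1ccc2noc(-c3ccc(Oc4ccccc4)cc3)c2c1`. In an assay for inhibition of inositol hexakisphosphate kinase 3 (Homo sapiens), read by colorimetric assay, coupled enzyme assay and malachite green, with a stated time of 120 min, in the presence of a further agent that is not named here (a higher number here means a weaker inhibitor, a lower number a stronger inhibitor), compound 1 gives 550 nM. Compound 2 `O=C(O)c1ccc2noc(-c3ccc(Oc4ncc(Cl)cc4Cl)cc3)c2c1` gives 2250 nM in this assay, and the step of a 4.1-fold higher number from compound 1 to compound 2 (0.61 log units; beyond the scatter) runs toward weaker inhibition. Compound 3 `CC(C)C(=O)Nc1ccc(-c2onc3ccc(C(=O)O)cc23)cc1` gives 210 nM in this assay and stands at the lowest number of the three measured compounds; the step of a 2.6-fold lower number from compound 1 to compound 3 (0.42 log units; beyond the scatter) and the step of an 11-fold lower number from compound 2 to compound 3 (1.03 log units; beyond the scatter) both favour the amide-bearing compound, the latter being the largest step seen so far.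

Compound 4 `O=C(O)c1ccc2noc(-c3ccc(NC(=O)c4ccncn4)cc3)c2c1` keeps the amide of compound 3 and alters only the group on its carbonyl carbon: pyrimidin-4-yl in place of isopropyl on a carbonyl carbon. Within the data shown here, none of the measured steps touches this carbonyl. All three concern the substituent on the aromatic carbon of the distal ring, where the phenoxy, the (3,5-dichloropyridin-2-yl)oxy and the (isopropylcarbonyl)amino groups were compared. Among the measured compounds shown here, the data therefore give no direct precedent for exchanging the isopropyl for a pyrimidin-4-yl, and the working assumption is a step of no size beyond the scatter, in either direction.

Compound 4 is accordingly expected to give about 250 nM, within 90 nM to 700 nM, in this assay. The estimated step of a 1.2-fold higher number from compound 3 to compound 4 (0.08 log units; within the scatter) is expected to lie within the scatter.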

Compound 4, half-maximal inhibitory concentration: 430 nM
Compound 4: the middle estimate sits 1.7-fold (0.24 log units) below what was measured; low and high end bracket the measured number.
By their numbers in this assay, from the lowest: compound 3; then compounds 4 and 1 (each within the scatter of the next); then compound 2.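

Among these compounds, the group on the carbonyl carbon of the amide now has a first reading in this assay: with a 2.0-fold higher number from compound 3 to compound 4 (0.31 log units; beyond the scatter) as its measure, pyrimidin-4-yl in place of isopropyl moves the number beyond the scatter, though only modestly, so this position responds to the change and still accepts a six-membered aromatic ring. The amide with this ring keeps a clear lead over the dichloropyridinyl ether, as a 5.2-fold lower number from compound 2 to compound 4 (0.72 log units; beyond the scatter) shows, but a 1.3-fold lower number from compound 1 to compound 4 (0.11 log units; within the scatter) lies within the scatter, so the edge over the phenoxy group seen with compound 3 does not hold for every group on this carbonyl carbon. No supporting data bear on the reason for this shift.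

The single exchange changes the ring and its 2 nitrogens together, so the compounds shown leave open whether the shift follows from the ring itself or from those nitrogens, a question that a phenyl or pyridin-4-yl group on the same carbon would address. Also open, as far as these compounds go, is how a cyclopropyl group, a longer chain or an amine would read at this position.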